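Shifting the Pyridine Nitrogen: From Compound 1 to Compound 4

The source may report more compounds than this note shows. Statements on the series, on what has been measured and on what is new or still open speak of the compounds shown alone.

Compound 1 `COc1cc(C(=O)/C=C/c2ccncc2)cc(OC)c1OC`: 7000 nM
Compound 2 `O=C(/C=C/c1ccncc1)c1ccccc1`: 49000 nM
Compound 3 `CN(C)c1cccc(C(=O)/C=C/c2ccncc2)c1`: 19000 nM

Of the compounds shown here, three have been tested in a functional assay with Rattus norvegicus as the target; a lower number here means a stronger inhibitor, a higher number a weaker inhibitor. Compound 1 gives the lowest number of the three, and both compound 3 and compound 2 lie beyond the scatter above it. Going by the values given here, the only single-point step among them, a 2.6-fold lower number from compound 2 to compound 3 (0.41 log units; beyond the scatter), concerns a dimethylamino group on an aromatic carbon and says nothing about the pyridine ring. Compound 4 `COc1cc(C(=O)/C=C/c2ccccn2)cc(OC)c1OC` differs from compound 1 by pyridin-2-yl in place of pyridin-4-yl on a double-bonded chain carbon bound to a double-bonded chain carbon. Among the compounds with values here, no measured pair tells how this assay responds to moving the ring nitrogen, so no direction can be read from the data, and the expected step, a 1.3-fold higher number from compound 1 to compound 4 (0.11 log units; within the scatter), is kept small. Compound 4 is therefore estimated at 9000 nM, within 3000 nM to 30000 nM.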

Compound 4, half-maximal inhibitory concentration: 18000 nM
The estimate for compound 4 lay 2.0-fold (0.30 log units) below the measured number, and the stated range covers the measured number.
By their numbers in this assay, from the lowest: compound 1; then compounds 4 and 3 (each within the scatter of the next); then compound 2.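

In this assay, pyridin-2-yl in place of pyridin-4-yl on this chain carbon gives a 2.6-fold higher number from compound 1 to compound 4 (0.41 log units; beyond the scatter), even though the two groups have the same atoms and the same counts of donors and acceptors. Going by these compounds alone, this is the first sign that the place of the ring nitrogen matters here, with pyridin-4-yl giving the lower number on the core of compound 1. Nothing available explains this shift. As far as these compounds go, how a pyridin-3-yl or a phenyl group would compare at this place remains open, as does whether the step carries over to the unsubstituted benzene ring of compound 2.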